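The compounds below may be only part of what the source reports. "The series", "measured", "known", "first", "only" and "open" are said of these compounds alone.

Compound 1 `CS(=O)(=O)c1ccc(Cc2nnc3n2N=C(c2ccccc2)CS3)cc1`: 55.5%
Compound 2 `CS(=O)(=O)c1ccc(Cc2nnc3n2N=C(c2cc(Cl)sc2S(N)(=O)=O)CS3)cc1`: 35.2%

In a functional assay on RAW264.7 cells (Mus musculus) for cytotoxicity, read by MTT assay, with a stated time of 48 h, tested at 100 uM (on this read-out higher numbers stand for a stronger effect at the one concentration tested and lower numbers for a weaker effect), compound 1 gives 55.5%, and compound 2 gives 35.2%. Compound 2 thus stands lowest of the two numbers, with compound 1 the nearest, as shown by the step of a number 20.3 percentage points lower from compound 1 to compound 2 (beyond the scatter). Compound 3 `CS(=O)(=O)c1ccc(Cc2nnc3n2N=C(c2cc(Cl)sc2Cl)CS3)cc1` has not yet been measured. It differs from compound 2 by chloro in place of sulfamoyl on an aromatic carbon. For the measured compounds named here, the only measured step exchanged phenyl for the whole thiophene group; none swaps sulfamoyl for chloro on its own, so that step bears on the present change only loosely. Going by the values given here, with no direct precedent, no step beyond the scatter is expected in this assay, and the estimate stays close to compound 2 with a wide range. Compound 3 is therefore expected to give about 40%, between 22% and 60%. The step this implies, a number 4.8 percentage points higher from compound 2 to compound 3 (within the scatter), is an expectation only.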

Compound 3, a percentage reported as activity, at one concentration (the size of the read-out at that concentration, not a potency): 47.3%
Compound 3: middle estimate off by 7.3 percentage points, on the low side; low and high end bracket the measured number.
By their numbers in this assay, from the lowest: compound 2; then compounds 3 and 1 (each within the scatter of the next).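

In this assay, chloro in place of sulfamoyl on the aromatic carbon next to the ring sulfur gives a number 12.1 percentage points higher from compound 2 to compound 3 (beyond the scatter) on its own, so this single position can shift the read-out, which the earlier exchange of a whole group could not show. Replacing phenyl with 2,5-dichlorothiophen-3-yl gives a number 8.2 percentage points lower from compound 1 to compound 3 (within the scatter) and so stays level with compound 1, which means that among these three compounds only the one bearing sulfamoyl differs clearly from compound 1. Nothing shown here explains these numbers.

The compounds shown leave open whether an amine, a carboxylic acid or a methyl group on this same carbon would read like chloro or like sulfamoyl. They also leave open what part, if any, the chloro two ring bonds away plays in these numbers.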